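This account rests on a few compounds, and the source may have more. Where it says the series, first, only, none or still open, it means among the compounds named here.

The measured compounds:

Compound 1, `OC[C@H]1OC(n2cnc3c(Nc4ccccc4)nccc32)[C@H](O)[C@@H]1O`, gives 10% in a functional assay on EL4 cells (Mus musculus) for inhibition, tested at 100 uM; a lower number here means less inhibition, a higher number more inhibition at the concentration tested (going by the name of the read-out).
Compound 2, `CCNc1nccc2c1ncn2C1O[C@H](CO)[C@@H](O)[C@H]1O`, gives 8%.
Compound 3, `OC[C@H]1OC(n2cnc3c(NCc4ccccc4)nccc32)[C@H](O)[C@@H]1O`, gives 5%.

The three compounds share one core and differ only in the group carried on a nitrogen on an aromatic ring. Compound 3 carries the benzyl there; its step from compound 1, a number 5 percentage points lower from compound 1 to compound 3 (within the scatter), and its step from compound 2, a number 3 percentage points lower from compound 2 to compound 3 (within the scatter), both stay within the scatter, as does the step of a number 2 percentage points lower from compound 1 to compound 2 (within the scatter). None of the three substituents on that nitrogen, then, moves the read-out beyond what repeated measurements would show on their own.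

Compound 4, `OC[C@H]1OC(n2cnc3c(S)nccc32)[C@H](O)[C@@H]1O`, goes further: sulfanyl in place of benzylamino on an aromatic carbon. Here the whole benzylamino group, nitrogen included, leaves and a single sulfur-bearing group enters in its place. Among the measured compounds shown here, no measured step covers a change of this kind; the three steps that do exist vary only what hangs on the nitrogen and were all within the scatter. On that basis compound 4 is expected to behave like its three relatives, with a step of a number 2 percentage points higher from compound 3 to compound 4 (within the scatter) that does not rise beyond the scatter. The estimate for compound 4 is 7%, within a range from 0% to 20%.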

Compound 4, a percentage reported as inhibition, at one concentration (the size of the read-out at that concentration, not a potency): < 5%
Compound 4: only a limit was reported; the forecaster's own chance of this, stated with the estimate: 5%; middle value at least 2 percentage points away from the limit.
By their numbers in this assay, from the lowest: compounds 3, 2 and 1 (each within the scatter of the next).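

In this assay, among the compounds shown here, compound 4 is reported only as a limit, < 5%, and it is the one value of the set that sits at that limit: the limit of < 5% in this assay, at which 1 of the 4 values shown sits. For the compounds shown here, this is the first change that replaces the whole group on the aromatic carbon next to the ring nitrogen, rather than only what hangs on its nitrogen, and it gives a number at least 3 percentage points lower from compound 2 to compound 4 (that floor lies within the scatter) and a number at least 5 percentage points lower from compound 1 to compound 4 (that floor lies within the scatter), while the remaining step is a number no higher from compound 3 to compound 4 (the limit leaves the size open). The number therefore shows no rise with the loss of the linking nitrogen, although both floors leave open whether sulfanyl truly lowers it beyond the scatter.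

The compounds shown do not settle whether any group on this carbon can lift the read-out beyond the scatter, since an unsubstituted amine, a methoxy or a chlorine there is not among them. They also leave open whether a longer chain on the sulfur, in place of the lone sulfanyl, would read differently from the amino-linked compounds.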